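The source may report more compounds than this note shows. Statements on the series, on what has been measured and on what is new or still open speak of the compounds shown alone.

Compound 1 `CC(=O)O[C@@H]1[C@@H](OC(C)=O)[C@@H](O)[C@@H](CO)O[C@H]1NC(=S)NNC(=O)Cn1cnc2c(N)ncnc21` and compound 3 `COc1ccc(C(=O)Nc2nc3ccccc3n2CC(=O)NNC(=S)N[C@@H]2O[C@H](CO)[C@H](O)[C@H](OC(C)=O)[C@H]2OC(C)=O)cc1` carry different cores, and the difference between the two cores is not broken down here. In a functional assay on Bel-7402 cells (Homo sapiens) for cytotoxicity, read by MTT assay, with a stated time of 48 h (a higher number here means that more compound is needed for the effect, a lower number that less compound is needed), compound 1 gives 86200 nM, while in this assay compound 3 gives 76400 nM; these two values lie within the usual scatter of each other. Compound 2 `CC(=O)O[C@@H]1[C@@H](OC(C)=O)[C@@H](O)CO[C@H]1NC(=S)NNC(=O)Cn1cnc2c(N)ncnc21` is compound 1 with hydrogen in place of hydroxymethyl on a saturated ring carbon. In this assay compound 2 reaches only a limit of the measurement, > 100000 nM. The step of an at least 1.1-fold higher number from compound 1 to compound 2 (0.06 log units; that floor lies within the scatter) thus has a floor that lies within the scatter, and its far end sits at the limit of > 100000 nM in this assay, at which 1 of the 3 values shown sits. Compound 4 `COc1ccc(C(=O)Nc2nc3ccccc3n2CC(=O)NNC(=S)N[C@@H]2OC[C@H](O)[C@H](OC(C)=O)[C@H]2OC(C)=O)cc1` is compound 3 with hydrogen in place of hydroxymethyl on a saturated ring carbon; the place of this change is described in the same words as for the change from compound 1 to compound 2, so it is the same change, made on a different core. That earlier change gave an at least 1.1-fold higher number from compound 1 to compound 2 (0.06 log units; that floor lies within the scatter). Because compound 3 gives 76400 nM and receives the same change, a step of a 1.6-fold higher number from compound 3 to compound 4 (0.20 log units; within the scatter) is expected. In this assay compound 4 is estimated to give 120000 nM, expected to fall between 55000 nM and 300000 nM, and a limit rather than a number is quite possible.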

Compound 4, half-maximal effective concentration: 36700 nM
Compound 4: the middle estimate sits 3.3-fold (0.51 log units) above what was measured; the measured number lies below the stated range.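

Replacing hydroxymethyl with hydrogen on the second core gives a 2.1-fold lower number from compound 3 to compound 4 (0.32 log units; beyond the scatter) in this assay, a modest step seen on this one core, which makes no rule for the series. Set beside the same change on the first core, this result neither shows that the change carries over from one core to the other nor shows that it fails to: the same change on two cores in this assay, an at least 1.1-fold higher number (0.06 log units; that floor lies within the scatter) from compound 1 to compound 2 and a 2.1-fold lower number (0.32 log units; beyond the scatter) from compound 3 to compound 4; the limit leaves it open whether they differ. Compound 2 gives > 100000 nM, which is a limit and not a number.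

The compounds shown leave open what other groups at this place on the ring would do, such as an amine, a carboxylic acid or a longer chain ending in a hydroxy group. They also leave open whether the lower number on the second core would hold if the two acetoxy groups were replaced by another group, such as a simple hydroxy group.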